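The compounds below may be only part of what the source reports. "The series", "measured", "known", "first", "only" and "open" are said of these compounds alone.

Compound 1, `O=C(CCC1=CCN(CCCc2ccc(Br)cc2)C1=O)NO` — 5100 nM; compound 2, `CCOc1ccc(CCCN2CC=C(CCC(=O)NO)C2=O)cc1` — 5100 nM; compound 3, `Cc1cccc(CCCN2CC=C(CCC(=O)NO)C2=O)c1` — 5100 nM.

In a functional assay on HCT-15 cells (Homo sapiens) for inhibition, read by sulforhodamine B assay (on this read-out higher numbers stand for weaker inhibition of growth and lower numbers for stronger inhibition of growth), all three measured compounds sit level. The two steps of no change at the digits printed from compound 1 to compound 2 (within the scatter) and no change at the digits printed from compound 1 to compound 3 (within the scatter) both change the aryl group on the chain and leave the number unmoved, so compound 3 stands level with compounds 1 and 2. Compound 4, `Cc1ccc(CCCN2CC=C(CCC(=O)NO)C2=O)cc1`, differs from compound 3 only by 4-methylphenyl in place of 3-methylphenyl on a saturated chain carbon, three bonds along the chain from an amide-type nitrogen in a ring. Among the compounds with values here, no measured step changes the aryl group and moves the read-out, so the shift of the methyl group is expected to give no step beyond the scatter, no change at the digits printed from compound 3 to compound 4 (within the scatter). Compound 4 is therefore estimated at 5100 nM, in a range from 2500 nM to 10000 nM.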

Compound 4, concentration for 50% growth inhibition: 5100 nM
The estimate for compound 4 equals the measured number at the digits printed, within the range that was stated.
By their numbers in this assay, from the lowest: compounds 1, 2, 3 and 4 (each within the scatter of the next).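

The step to 4-methylphenyl in place of 3-methylphenyl gives no change at the digits printed from compound 3 to compound 4 (within the scatter) in this assay and shows that moving the methyl around the aromatic ring leaves the read-out unmoved. With methyl in place of ethoxy on an aromatic carbon the result is no change at the digits printed from compound 2 to compound 4 (within the scatter) and with methyl in place of bromo it is no change at the digits printed from compound 1 to compound 4 (within the scatter) as well, so these compounds offer no aryl change that moves the number. Nothing measured here explains this flat result.

Going by these compounds, whether an amine or a carboxylic acid on the aromatic ring would also leave the number unmoved stays open. So does the effect of a longer chain between the ring and the amide-type nitrogen.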